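Cytotoxicity notes: bromothiophene for phenyl in the amine arm

The compounds below may be only part of what the source reports. "The series", "measured", "known", "first", "only" and "open" are said of these compounds alone.

Measured so far in an ADME assay on A549 cells (Homo sapiens) for cytotoxicity, read by resazurin assay, with a stated time of 48 h; a lower number here means that less compound is tolerated, a higher number that more compound is tolerated:
- compound 1 `CC1(ON(c2ccc(NC(=O)c3cc(Cl)ccc3O)c(Cl)c2)C2(C)CCCC2)CCCC1` gives 18000 nM
- compound 2 `O=C(Nc1ccc(NCc2ccccc2)cc1Cl)c1cc(Cl)ccc1O` gives 19700 nM
- compound 3 `O=C(Nc1ccc(NCc2cc(F)cc(C(F)(F)F)c2)cc1Cl)c1cc(Cl)ccc1O` gives 30900 nM

Compound 2 stands second highest of the three numbers. Its nearest neighbour is compound 1, whose number is lower by a margin within the scatter; its furthest is compound 3, whose number is higher, again within the scatter. All three values therefore sit within the scatter of one another, and no order among them can be read. Among the measured compounds shown here, none of the pairs differs in only one place, so no single-point step is available.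

Compound 4 `O=C(Nc1ccc(NCc2ccc(Br)s2)cc1Cl)c1cc(Cl)ccc1O` is not yet measured. It differs from compound 2 as follows: 5-bromothiophen-2-yl in place of phenyl on a saturated chain carbon bound to a nitrogen on an aromatic ring. For the measured compounds named here, nothing among the measured compounds shows how this change acts in this assay; all that is known is that compound 2 and compound 3, which differ in the same arm, give numbers within the scatter of each other. No step beyond the scatter is expected in this assay in either direction, so the step from compound 2 to compound 4 is estimated at a 1.1-fold higher number from compound 2 to compound 4 (0.03 log units; within the scatter). Compound 4 is expected to give about 21000 nM, with a range from 9000 nM to 48000 nM.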

Compound 4, half-maximal cytotoxic concentration: 20700 nM
Compound 4: middle estimate off by 1.0-fold (0.01 log units), on the high side; the measured number falls inside the stated range.
By their numbers in this assay, from the lowest: compounds 1, 2, 4 and 3 (each within the scatter of the next).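

In this assay, among the compounds shown here, the exchange of phenyl for 5-bromothiophen-2-yl, on a saturated chain carbon bound to a nitrogen on an aromatic ring, gives a 1.1-fold higher number from compound 2 to compound 4 (0.02 log units; within the scatter) and is the first step that differs in one place. For the compounds shown here, it shows directly that this position accepts a five-membered aromatic ring with 1 hetero atom, carrying a bromine, with no step beyond the scatter; the earlier compounds offered no such pair. Nothing measured here speaks to the reason for this result.

The two parts of the change remain unseparated, since plain thiophen-2-yl without the bromine is not among the compounds shown. Also open, from the compounds shown here alone, is whether this arm stays within the scatter with a group of another kind in place of the aromatic ring, such as a carboxylic acid or an amine.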